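Chloro for fluoro on the fused ring of compound 2

The source may hold more compounds than are shown below. What is called first, only, known or untested is meant among the compounds shown, and "the series" means these compounds.

Compound 1 `O=C(CCCSc1nc2cc(Cl)ccc2o1)N1CCCC1`: 3.4 mL/min/g
Compound 2 `O=C(CCSc1nc2cc(F)ccc2o1)N1CCS(=O)(=O)CC1`: 0.4 mL/min/g
Compound 3 `CS(=O)(=O)N1CCN(C(=O)CCSc2nc3cc(Cl)ccc3o2)CC1`: 0.6 mL/min/g

Of the compounds shown here, three sharing one core have been measured in an ADME assay on microsomes from liver (Homo sapiens) for metabolic stability, read by LC-MS, using NADPH, with a stated time of 45 min, tested at 0.5 uM; a lower number here means slower removal, a higher number faster removal of the compound. Compound 2 gives the lowest number of the three, 0.4 mL/min/g. Its nearest neighbour is compound 3, whose 0.6 mL/min/g lies within the scatter of compound 2, so the two cannot be ordered. Compound 1 stands furthest away, with 3.4 mL/min/g, a gap beyond the scatter.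

Compound 4 `O=C(CCSc1nc2cc(Cl)ccc2o1)N1CCS(=O)(=O)CC1` is not yet measured. It differs from compound 2 in one place: chloro in place of fluoro on an aromatic carbon. The place is an aromatic carbon of the six-membered carbon-only ring of the fused system, meta to a fused ring and para to a fused ring.

For the measured compounds named here, no single-change step between measured compounds is available to calibrate this change. Compound 3, which also carries chloro, gives 0.6 mL/min/g, within the scatter of compound 2, so a small step in this assay, if any, is expected, leaning upward. The step from compound 2 to compound 4 is estimated as a 1.8-fold higher number from compound 2 to compound 4 (0.24 log units; within the scatter). Compound 4 is expected to give about 0.7 mL/min/g, in a range from 0.3 mL/min/g to 1.6 mL/min/g.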

Compound 4, intrinsic clearance in a liver preparation (reported as CLH), per the amount of preparation that the assay uses: 0.4 mL/min/g
For compound 4 the middle estimate is 1.8-fold (0.24 log units) above the measured one, within the range that was stated.
By their numbers in this assay, from the lowest: compounds 2, 4 and 3 (each within the scatter of the next); then compound 1.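

In this assay, chloro in place of fluoro on this aromatic carbon, meta to a fused ring and para to a fused ring, gives no change at the digits printed from compound 2 to compound 4 (within the scatter). For the compounds shown here, no earlier pair differed in this one place alone, so this is the first direct reading of the change, and it shows that, with the rest of compound 2 kept as it is, the two halogens cannot be told apart here. Nothing available explains this result.

The compounds shown leave open whether a group other than a halogen on this carbon, such as methoxy, a nitrile or an amine, would move the number beyond the scatter. They also leave open whether chloro and fluoro would stand as level with the other side chains, such as the longer chain of compound 1.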